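Ester variation on the shared core: expectation for compound 4

This account rests on a few compounds, and the source may have more. Where it says the series, first, only, none or still open, it means among the compounds named here.

Three esters of the shared core have been measured in a functional assay on MDA-MB-231 cells (Homo sapiens) for antiproliferative activity, read by MTT assay, with a stated time of 72 h; a lower number here means a stronger inhibitor, a higher number a weaker inhibitor. Compound 1 `CC1=CC[C@H]2[C@H](CC[C@]2(C)O)C(C)(C)[C@@H]1CC[C@H]1[C@]2(C)CC[C@H](OC(=O)CCC(=O)O)C(C)(C)O[C@H]2CC[C@@]1(C)O` gives 27900 nM, compound 2 `CC1=CC[C@H]2[C@@H]1CC=C(C)[C@@H](CC[C@H]1[C@]3(C)CC[C@H](OC(=O)c4ccncc4)C(C)(C)O[C@H]3CC[C@@]1(C)O)C2(C)C` gives 19100 nM, and compound 3 `CC1=CC[C@H]2[C@H](CC[C@]2(C)O)C(C)(C)[C@@H]1CC[C@H]1[C@]2(C)CC/C(=N/OC(=O)c3ccccc3)C(C)(C)O[C@H]2CC[C@@]1(C)O` gives 27400 nM. Compound 1 has the highest number of the three, but its gaps to compound 3 and to compound 2 both lie within the scatter, so no order among them can be read. Compound 4 `CC1=CC[C@H]2[C@H](CC[C@]2(C)O)C(C)(C)[C@@H]1CC[C@H]1[C@]2(C)CC[C@H](OC(=O)c3ccccc3C(F)(F)F)C(C)(C)O[C@H]2CC[C@@]1(C)O` is not yet measured; it differs from compound 1 by 2-(trifluoromethyl)phenyl in place of 2-carboxyethyl on a carbonyl carbon. Going by the values given here, no measured pair isolates this change. Compound 2 with 19100 nM and compound 3 with 27400 nM carry aromatic acyl groups on the same core and sit near compound 1. Compound 4 is therefore expected to show a step of a 1.3-fold lower number from compound 1 to compound 4 (0.12 log units; within the scatter), small and not clearly beyond the scatter. Compound 4 is estimated at 21000 nM, within 9000 nM to 50000 nM.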

Compound 4, half-maximal inhibitory concentration: 31500 nM
Compound 4: middle estimate off by 1.5-fold (0.18 log units), on the low side; the measured number falls inside the stated range.
By their numbers in this assay, from the lowest: compounds 2, 3, 1 and 4 (each within the scatter of the next).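

In this assay, going by these compounds alone, 2-(trifluoromethyl)phenyl in place of 2-carboxyethyl on a carbonyl carbon gives a step within the scatter (a 1.1-fold higher number from compound 1 to compound 4 (0.05 log units; within the scatter)), the only isolated change at this position so far. Even an exchange that loses the hydrogen-bond donor and acceptor of 2-carboxyethyl and brings in an aromatic ring therefore produces no readable difference. No measurement at hand explains this result.

On these data alone, whether an amine or a longer alkyl chain on this carbonyl carbon would give a step beyond the scatter remains open. No group shown so far separates from the others.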